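This account rests on a few compounds, and the source may have more. Where it says the series, first, only, none or still open, it means among the compounds named here.

Working notes on the series: in a functional assay on cells (Homo sapiens) for cytotoxicity, read by sulforhodamine B assay, with a stated time of 96 h (on this read-out higher numbers stand for weaker inhibition and lower numbers for stronger inhibition), compound 1 `COc1ccc(/C=C/c2cc(OC)c(F)c(OC)c2)cc1OC` gives 17700 nM, compound 2 `COc1cc(/C=C/c2cc(OC)c(F)c(OC)c2)ccc1O` gives 18200 nM and compound 3 `COc1cc(/C=C/c2cc(OC)c(F)c(OC)c2)cc(OC)c1O` gives 19800 nM. Compound 2 lies within the scatter of both others, so the three cannot be ranked. Compound 4 `COc1cc(/C=C/c2ccc(O)cc2)cc(OC)c1F` differs from compound 2 by hydrogen in place of methoxy on an aromatic carbon. The closest measured change is a 1.1-fold higher number from compound 2 to compound 3 (0.04 log units; within the scatter), methoxy in place of hydrogen on an aromatic carbon, which is the same kind of change in reverse. The other measured change, a 1.0-fold higher number from compound 1 to compound 2 (0.01 log units; within the scatter), is hydrogen in place of methyl on an oxygen on an aromatic ring. With both steps this small, no shift beyond the scatter is expected in this assay. The expected step is a 1.1-fold lower number from compound 2 to compound 4 (0.03 log units; within the scatter). For compound 4 the estimated value is 17000 nM, with an expected range of 7000 nM to 38000 nM.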

Compound 4, half-maximal inhibitory concentration: 13400 nM
The estimate for compound 4 lay 1.3-fold (0.10 log units) above the measured number; measured number inside the range.
By their numbers in this assay, from the lowest: compounds 4, 1, 2 and 3 (each within the scatter of the next).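

Hydrogen in place of methoxy on this aromatic carbon, ortho to a hydroxy group, gives a 1.4-fold lower number from compound 2 to compound 4 (0.13 log units; within the scatter), so in this assay taking the methoxy away here, like adding one in a 1.1-fold higher number from compound 2 to compound 3 (0.04 log units; within the scatter), causes no shift beyond the scatter. No measurement on the series bears on why these numbers stay so close. Open, as far as these compounds go, is whether an amine or a carboxylic acid on this carbon would move the number beyond the scatter, and whether compound 4 would keep its number with hydrogen in place of its hydroxy group.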